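From bromo to methyl on the benzyl group

The source may report more compounds than this note shows. Statements on the series, on what has been measured and on what is new or still open speak of the compounds shown alone.

Measured in a functional assay on MCF cells (Homo sapiens) for antiproliferative activity, with a stated time of 72 h; a lower number here means a stronger inhibitor, a higher number a weaker inhibitor:
Compound 1 `OC[C@H]1O[C@@H](n2cnc3c(NCc4ccccc4F)ncnc32)[C@H](O)[C@@H]1O`: > 166000 nM (a limit)
Compound 2 `OC[C@H]1O[C@@H](n2cnc3c(NCc4cccc(F)c4)ncnc32)[C@H](O)[C@@H]1O`: 15300 nM
Compound 3 `OC[C@H]1O[C@@H](n2cnc3c(NCc4ccc(Br)cc4)ncnc32)[C@H](O)[C@@H]1O`: > 166000 nM (a limit)

Compound 3 stands at the limit of > 166000 nM in this assay, at which 2 of the 3 values shown sit. Compound 4 `Cc1ccc(CNc2ncnc3c2ncn3[C@@H]2O[C@H](CO)[C@@H](O)[C@H]2O)cc1` carries methyl in place of bromo on an aromatic carbon, para to a large group (methyl in place of bromo on an aromatic carbon).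

Three measured steps change the group on the same phenyl. Two are large: an at least 10-fold lower number from compound 1 to compound 2 (1.03 log units; beyond the scatter) and an at least 10-fold higher number from compound 2 to compound 3 (1.03 log units; beyond the scatter). The third, a step that the two limits leave unreadable from compound 1 to compound 3, cannot be sized. None of them exchanges bromo for methyl, so the evidence is indirect, and a limit may well recur in this assay. A modest move to a lower number is expected, given as an at least 2.0-fold lower number from compound 3 to compound 4 (0.31 log units; beyond the scatter). Compound 4 is estimated at 80000 nM, with an expected range from 15000 nM to 250000 nM.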

Compound 4, half-maximal inhibitory concentration: > 166000 nM
Compound 4 was reported as a limit (the forecaster's own chance of this, stated with the estimate: 55%); middle value at least 2.0-fold (0.31 log units) from the limit.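

In this assay, compound 4 also gives only a limit, > 166000 nM, so methyl at this position, like bromo, yields no readable number. Among these compounds, the steps from compound 1 and compound 3 to this compound cannot be read, but the one step that can be read gives an at least 10-fold higher number from compound 2 to compound 4 (1.03 log units; beyond the scatter), replacing the 3-fluorophenyl group with 4-methylphenyl. Only compound 2 now has a measured number, and the limit accounts for the rest of the series: the limit of > 166000 nM in this assay, at which 3 of the 4 values shown sit.

As far as these compounds go, whether methyl and bromo differ at all remains open. So does whether an amine or a carboxylic acid on this aromatic carbon would give a readable value.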